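A few compounds are considered here, and "the series" means these few. Any claim that something is new, unique, unknown or untested is made for them only; others in the source may bear on it.

Compound 1, `O=C(Nc1cccc(-n2cc(-c3ccncc3)c(-c3cc(O)cc(Cl)c3)n2)c1)Nc1ccc(Cl)c(C(F)(F)F)c1`: in a functional assay on SK-MEL-28 cells (Homo sapiens) for inhibition, read by sulforhodamine B assay, with a stated time of 48 h, tested at 0.1 uM (on this read-out lower numbers stand for a stronger effect and higher numbers for a weaker effect at the one concentration tested), compound 1 gives 100%.
Compound 2, `O=C(Nc1cccc(-n2cc(-c3ccncc3)c(-c3cc(O)cc(Cl)c3)n2)c1)Nc1ccc(Cl)c(Cl)c1`: in this assay compound 2 gives 97%.
Compound 3, `COc1cc(Cl)cc(-c2nn(-c3cccc(NC(=O)Nc4ccc(Cl)c(C(F)(F)F)c4)c3)cc2-c2ccncc2)c1`: in this assay compound 3 gives 106%.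

Compound 3 holds the highest of these three numbers, but only by a small margin: its nearest neighbour is compound 1, with a number 6 percentage points higher from compound 1 to compound 3 (within the scatter), and the values of compound 3 and compound 2 also lie close to each other. None of the three compounds shows an effect that stands out from the others.

Compound 4, `COc1cc(Cl)cc(-c2nn(-c3cccc(NC(=O)Nc4ccc(Cl)c(Cl)c4)c3)cc2-c2ccncc2)c1`, differs from compound 3 in one place: chloro in place of trifluoromethyl on an aromatic carbon. For the measured compounds named here, one measured step bears directly on this change, the same replacement on the same ring between compound 1 and compound 2, which gave a number 3 percentage points lower from compound 1 to compound 2 (within the scatter). On that basis no step beyond the scatter is expected in this assay for compound 4 in either direction. Compound 4 is therefore estimated at 103%, with a range from 93% to 113%. This estimate means a number 3 percentage points lower from compound 3 to compound 4 (within the scatter) is expected.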

Compound 4, a percentage reported as activity, at one concentration (the size of the read-out at that concentration, not a potency): 103%
For compound 4 middle estimate and measured number coincide at the digits printed, and the stated range covers the measured number.
By their numbers in this assay, from the lowest: compounds 2, 1, 4 and 3 (each within the scatter of the next).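

Compound 4 gives a second reading of chloro in place of trifluoromethyl in this assay, a number 3 percentage points lower from compound 3 to compound 4 (within the scatter), and the two readings agree: the same change on two cores in this assay, a number 3 percentage points lower (within the scatter) from compound 1 to compound 2 and a number 3 percentage points lower (within the scatter) from compound 3 to compound 4, 0 percentage points apart, within the scatter of two such steps. It also gives a second reading of methyl in place of hydrogen on the oxygen, now with the 3,4-dichlorophenyl group present, a number 6 percentage points higher from compound 2 to compound 4 (within the scatter), and these readings agree as well: the same change on two cores in this assay, a number 6 percentage points higher (within the scatter) from compound 1 to compound 3 and a number 6 percentage points higher (within the scatter) from compound 2 to compound 4, 0 percentage points apart, within the scatter of two such steps. On the compounds shown, neither change moves the read-out beyond the scatter on either core, and the two changes together, as far as these four compounds show, leave the read-out flat at the one concentration tested.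

On these data alone, whether an amine or a nitrile in place of the trifluoromethyl, or a longer chain on the oxygen, would shift the read-out remains open. As far as these compounds go, how these compounds would read at any other concentration also remains open.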